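A few compounds are considered here, and "the series" means these few. Any claim that something is new, unique, unknown or untested is made for them only; others in the source may bear on it.

Measured so far:
- compound 1, `Cc1cccc(N2CCN(C(=O)CN3C(=O)CC(C)(c4ccccc4)C3=O)CC2)c1`: 100 mg/kg
- compound 2, `COc1cccc(N2CCN(C(=O)CN3C(=O)CC(C)(c4ccccc4)C3=O)CC2)c1`: "not active" (no number reported)
- compound 3, `CC1(c2ccccc2)CC(=O)N(CC(=O)N2CCN(c3cccc(Cl)c3Cl)CC2)C1=O`: "not active" (no number reported)

Within the data shown here, the shared core carries an aryl group on the amine nitrogen of the six-membered ring with two nitrogens, and only this aryl group varies. In a functional assay on the whole organism (strain CD-1) with Mus musculus as the target, in the maximal electroshock model, with a stated time of 0.5 h (a lower number here means that less compound is needed, a higher number that more compound is needed for the effect), compound 1 gives 100 mg/kg, the only numbered result in the set. Compound 2 gives "not active" (no number reported) in this assay, so no number stands for it; compound 3 is the one further entry that is likewise without a single number. Among the measured compounds shown here, two of three measured compounds thus fall outside what this assay reports as a number, and the one numbered value sits high.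

The step to compound 4, `CC1(c2ccccc2)CC(=O)N(CC(=O)N2CCN(c3ccc(Cl)c(Cl)c3)CC2)C1=O`, changes the aryl group: 3,4-dichlorophenyl in place of 3-methoxyphenyl on an amine nitrogen in a ring. For the measured compounds named here, no step between measured compounds is available, and compound 2 itself has no number, so the size of the step from compound 2 to compound 4 in this assay cannot be set from a difference. The expectation is that compound 4 lands near compound 1 at best, with a substantial chance that this assay again reports no number, since neither compound 2 with "not active" (no number reported) nor compound 3 with "not active" (no number reported) gave one.

For compound 4 in this assay the estimate is 100 mg/kg, within the range 30 mg/kg to 300 mg/kg.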

Compound 4, minimum effective dose: "not active" (no number reported)
Compound 4: no number reported; the estimate stays without a comparison.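

In this assay neither compound 2 nor compound 4 gives a number, so no step can be read between them. No data shown here bear on the reason for this outcome. Compound 1 with 100 mg/kg stays the only numbered result, and the compounds shown leave open whether another aryl group on the shared core would give a number at all.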